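From Methylcyclopropyl to Phenyl on Compound 2

The source may hold more compounds than are shown below. What is called first, only, known or untested is meant among the compounds shown, and "the series" means these compounds.

In a functional assay on a cell-free system (plasma, Homo sapiens), with a stated time of 3 min (on this read-out higher numbers stand for weaker inhibition and lower numbers for stronger inhibition), compound 2 (`CC1(C[C@@H](O)C(=O)N2N=CC[C@H]2C(=O)NCc2cc(Cl)ccc2-n2cnnn2)CC1`) gives 730 nM. Compound 1 (`Cc1cccc([C@@H](O)C(=O)N2N=CC[C@H]2C(=O)NCc2cc(Cl)ccc2-n2cnnn2)c1`) gives 830 nM, and compound 3 (`O=C(NCc1cc(Cl)ccc1-n1cnnn1)[C@@H]1C[C@@H]2C[C@@H]2N1C(=O)[C@H](O)C1CCCCC1`) gives 600 nM. All three numbers lie within the usual scatter of one another, so compound 2 cannot be ranked against either neighbour.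

Compound 4 (`O=C(NCc1cc(Cl)ccc1-n1cnnn1)[C@@H]1CC=NN1C(=O)[C@H](O)Cc1ccccc1`) has not yet been measured. Its structure departs from that of compound 2 in one place: phenyl in place of 1-methylcyclopropyl on a saturated chain carbon, two bonds along the chain from a carbonyl carbon and an oxygen on a saturated carbon. Put simply, (1-methylcyclopropyl)methyl gives way to benzyl.

Within the data shown here, only one measured step bears on this change: a 1.1-fold lower number from compound 1 to compound 2 (0.06 log units; within the scatter). There, (1-methylcyclopropyl)methyl replaced 3-methylphenyl, and the number stayed within the scatter. Among the measured compounds shown here, compound 3 is linked to the others by no single-place step, so it adds only a sense of the range seen so far. For the measured compounds named here, one step is thin evidence, and no benzyl compound has been measured yet. Even so, a large move is not what the data suggest, so no change beyond the scatter is expected in this assay, and the expected step is a 1.0-fold higher number from compound 2 to compound 4 (0.01 log units; within the scatter). For compound 4 the estimated value is 750 nM, within an expected range of 330 nM to 1700 nM.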

Compound 4, half-maximal inhibitory concentration: 1400 nM
For compound 4 the middle estimate is 1.9-fold (0.27 log units) below the measured one, and the stated range covers the measured number.
By their numbers in this assay, from the lowest: compounds 3, 2, 1 and 4 (each within the scatter of the next, the first and the last beyond it).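

In this assay the change of 1-methylcyclopropyl to phenyl gives a 1.9-fold higher number from compound 2 to compound 4 (0.28 log units; within the scatter), so swapping a three-membered non-aromatic ring for a six-membered aromatic ring at this position produces no difference that can be read, even though the entering group has more heavy atoms. The second new step, a 1.7-fold higher number from compound 1 to compound 4 (0.23 log units; within the scatter), points the same way: 3-methylphenyl, (1-methylcyclopropyl)methyl and benzyl, the three groups now compared on this part of the core, cannot be told apart in this read-out, and a group of either ring type can stand here without a readable change. Nothing available offers an explanation for these numbers or shows how these groups act at this position.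

On these data alone, all three groups are built of carbon only and carry no hydrogen-bond donors or acceptors, so it remains open whether an amine, a carboxylic acid or a hydroxyl group on the same chain carbon would move the number beyond the scatter in this assay. It is also open whether a longer chain ending in phenyl would still leave the number within the scatter of these compounds.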